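Swapping an aryl group for furan in a thiazole series

The compounds below may be only part of what the source reports. "The series", "measured", "known", "first", "only" and "open" are said of these compounds alone.

Measured so far:
Compound 1, `Cc1nc(NC(=O)c2ccccc2)sc1C(=O)/C=C/c1ccccc1`, in an assay for inhibition of Polyunsaturated fatty acid 5-lipoxygenase (Homo sapiens), read by spectrophotometry, tested at 10 uM, in the presence of a further agent that is not named here (on this read-out higher numbers stand for more inhibition at the one concentration tested (going by the name of the read-out) and lower numbers for less inhibition), gives 73.5%.
Compound 2, `Cc1nc(NC(=O)c2ccccc2)sc1C(=O)/C=C/c1ccc(N(C)C)cc1`, in this assay gives 88.2%.

Compound 2 stands highest of the two numbers; its nearest neighbour is compound 1, with the step of a number 14.7 percentage points higher from compound 1 to compound 2 (beyond the scatter). Compound 3, `Cc1nc(NC(=O)c2ccccc2)sc1C(=O)/C=C/c1ccco1`, carries furan-2-yl in place of 4-(dimethylamino)phenyl on a double-bonded chain carbon bound to a double-bonded chain carbon. Among the measured compounds shown here, the one measured step that bears on this is the gain from adding dimethylamino, a number 14.7 percentage points higher from compound 1 to compound 2 (beyond the scatter); compound 3 loses that group and its ring shrinks, so a drop beyond the scatter is expected, roughly undoing that gain. Compound 3 is therefore expected at 70%, between 55% and 85%, a step of a number 18.2 percentage points lower from compound 2 to compound 3 (beyond the scatter).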

Compound 3, a percentage reported as inhibition, at one concentration (the size of the read-out at that concentration, not a potency): 57.2%
Compound 3: middle estimate off by 12.8 percentage points, on the high side; measured number inside the range.
By their numbers in this assay, from the lowest: compound 3; then compound 1; then compound 2.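

The furan-2-yl ring is a poorer choice at this chain carbon than either six-membered ring tested: it falls short of 4-(dimethylamino)phenyl (a number 31 percentage points lower from compound 2 to compound 3 (beyond the scatter)) and also of plain phenyl (a number 16.3 percentage points lower from compound 1 to compound 3 (beyond the scatter)). Compound 2 carries a dimethylamino group and compound 1 does not. The phenyl of compound 1 also beats furan-2-yl. No measurement here explains this ranking.

As far as these compounds go, it remains open how a thiophene or pyridine ring would compare at this place. From the compounds shown here alone, it is equally open whether a dimethylamino group on the furan would recover the lost inhibition.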